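From methyl to cyclopropyl on compound 1

The source may report more compounds than this note shows. Statements on the series, on what has been measured and on what is new or still open speak of the compounds shown alone.

Among the compounds with values here, in a functional assay on HeLa cells (Homo sapiens) for antiproliferative activity, read by sulforhodamine B assay (a higher number here means a weaker inhibitor of growth, a lower number a stronger inhibitor of growth), compound 1 (`CC[C@@H]1O[C@H](COCc2ccccc2)[C@@H](OCc2ccccc2)[C@H](OCc2ccccc2)[C@H]1O`) gives 19800 nM and holds the only true number among the three compounds measured. Compound 2 (`CC[C@H]1O[C@H](COCc2ccccc2)[C@@H](OCc2ccccc2)[C@H](OCc2ccccc2)[C@H]1O`) shows > 50000 nM which is a limit of this assay and not a number. Compound 3 (`CCCCCCCCCCCCCCCOC[C@H]1O[C@@H](CCC)[C@H](O)[C@@H](OCCCCCCCCCCCCCCC)[C@@H]1OCCCCCCCCCCCCCCC`) shows > 50000 nM which is likewise only a limit.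

Compound 4 (`O[C@@H]1[C@@H](OCc2ccccc2)[C@H](OCc2ccccc2)[C@@H](COCc2ccccc2)O[C@H]1CC1CC1`) has cyclopropyl in place of methyl on a saturated chain carbon bound to a saturated ring carbon as its change. Within the data shown here, the one measured step (an at least 2.5-fold higher number from compound 1 to compound 2 (0.40 log units; beyond the scatter)) concerns configuration alone (the fact that compounds 1 and 2 differ only in the configuration as drawn) and ends at the limit (the limit of > 50000 nM in this assay, at which 2 of the 3 values shown sit) so it does not bear directly on this change. Among the measured compounds shown here, no measured step alters this group. The expected step (a 1.0-fold higher number from compound 1 to compound 4 (0.00 log units; within the scatter)) is therefore estimated to stay within the scatter. Compound 4 is expected at about 20000 nM with an estimated range of 8000 nM to 50000 nM in this estimate.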

Compound 4, concentration for 50% growth inhibition: > 50000 nM
Compound 4 was reported as a limit (the forecaster's own chance of this, stated with the estimate: 30%); middle value at least 2.5-fold (0.39 log units) away from the limit.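

Replacing methyl with cyclopropyl on a saturated chain carbon bound to a saturated ring carbon gives, in this assay, an at least 2.5-fold higher number from compound 1 to compound 4 (0.40 log units; beyond the scatter), the first step shown that alters this group rather than the configuration as drawn. Compound 4 gives > 50000 nM, which is a limit of this assay and not a number. The step therefore fixes a direction but not a size: the limit of > 50000 nM in this assay, at which 3 of the 4 values shown sit.

As far as these compounds go, it remains open whether an amine or a carboxylic acid in place of this methyl would retain the growth inhibition of compound 1.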